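The source may report more compounds than this note shows. Statements on the series, on what has been measured and on what is new or still open speak of the compounds shown alone.

Compound 1 `COc1cccc(NC(=S)Nc2cccc(C(F)(F)F)c2)c1`: 26000 nM
Compound 2 `C=C(C)CNC(=S)Nc1cccc(C(F)(F)F)c1`: 43000 nM
Compound 3 `CCCCc1ccc(NC(=S)Nc2cccc(C(F)(F)F)c2)c(C)c1`: 43000 nM

All three compounds were tested in an ADME assay on MT4 cells (Homo sapiens) for cytotoxicity; on this read-out higher numbers stand for lower toxicity in this test and lower numbers for higher toxicity in this test. On these numbers compound 2 stands level with compound 3 at the digits shown, and the two together give the highest values of the three; compound 1 gives a lower number, but the gap from compound 2 to compound 1 lies within the usual scatter of repeated measurements, so none of the three can be called more or less toxic than another on this evidence.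

Compound 4 `Fc1ccc(NC(=S)Nc2cccc(C(F)(F)F)c2)cc1` has not yet been measured in this assay. Compared with compound 2 its structure differs in one place: 4-fluorophenyl in place of 2-methylprop-2-en-1-yl on an amide-type nitrogen. For the measured compounds named here, no measured pair shows a change of this kind, so the expectation rests only on the narrow band that compounds 1, 2 and 3 occupy, with all three values close to one another. Compound 4 is therefore expected to stay in that band, and the step from compound 2 is estimated as a 1.3-fold lower number from compound 2 to compound 4 (0.13 log units; within the scatter), which is no change beyond the scatter. The expected value for compound 4 in this assay is 32000 nM, with a likely range from 13000 nM to 75000 nM.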

Compound 4, half-maximal cytotoxic concentration: 31000 nM
Compound 4: the middle estimate sits 1.0-fold (0.01 log units) above what was measured; measured number inside the range.
By their numbers in this assay, from the lowest: compounds 1, 4, 2 and 3 (each within the scatter of the next).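

Placing 4-fluorophenyl in place of 2-methylprop-2-en-1-yl on the amide-type nitrogen gives, in this assay, a 1.4-fold lower number from compound 2 to compound 4 (0.14 log units; within the scatter). For the compounds shown here, this is the first pair here that differs in one place, and it shows that this nitrogen can carry either an open chain with a double bond or a six-membered aromatic ring bearing fluorine with no change beyond the scatter. Nothing measured here indicates what lies behind this reading.

The pair says nothing about whether a plain phenyl without the fluorine would fall within the same scatter. It also leaves open whether a carboxylic acid, an amine or a much longer carbon chain on this nitrogen would shift the number beyond the scatter.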